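Bromo for chloro on the aryl ketone of compound 1

The source may report more compounds than this note shows. Statements on the series, on what has been measured and on what is new or still open speak of the compounds shown alone.

Measured compounds in a functional assay on DU-145 cells (Homo sapiens) for inhibition, read by trypan blue exclusion, with a stated time of 96 h; a higher number here means a weaker inhibitor of growth, a lower number a stronger inhibitor of growth:
compound 1, `CSc1ccc(/C=C(\C(=O)c2ccc(Cl)cc2)S(=O)(=O)Cc2ccc(C)cc2)cc1`, 10000 nM
compound 2, `Cc1ccc(CS/C(=C/c2c[nH]c3ccc(Br)cc23)C(=O)c2ccc(Cl)cc2)cc1`, 1000 nM
compound 3, `Cc1ccc(CS/C(=C/c2c[nH]c3ccc(Cl)cc23)C(=O)c2ccc(Cl)cc2)cc1`, 1000 nM

In this assay compound 1 stands at the highest of the three numbers. Compound 3 and compound 2 differ by bromo in place of chloro on an aromatic carbon, and that step, no change at the digits printed from compound 3 to compound 2 (within the scatter), stays within the scatter. The difference between the core of compound 1 and the core of compound 3 is not broken down here.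

Compound 4, `CSc1ccc(/C=C(\C(=O)c2ccc(Br)cc2)S(=O)(=O)Cc2ccc(C)cc2)cc1`, is not yet measured. It differs from compound 1 by bromo in place of chloro on an aromatic carbon. This is the same kind of change as from compound 3 to compound 2, not the same: there the place is part of a fused system of two rings, meta to a fused ring and para to a fused ring; here it is on a ring of carbon only, para to a large group. Because no change at the digits printed from compound 3 to compound 2 (within the scatter) showed no change, the step from compound 1 to compound 4 is expected to be small, no change at the digits printed from compound 1 to compound 4 (within the scatter). Compound 4 is therefore estimated at 10000 nM in this assay, with 5000 nM to 20000 nM as the expected range.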

Compound 4, concentration for 50% growth inhibition: 10000 nM
Compound 4: the middle estimate sits on the measured number at the digits printed, within the range that was stated.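

In this assay, the change from (4-chlorophenyl)carbonyl to (4-bromophenyl)carbonyl gave no change at the digits printed from compound 1 to compound 4 (within the scatter). Set beside the same exchange of chloro for bromo at a different place on another core, the two steps agree: the same change on two cores in this assay, no change at the digits printed (within the scatter) from compound 3 to compound 2 and no change at the digits printed (within the scatter) from compound 1 to compound 4, 1.0-fold (0.00 log units) apart, within the scatter of two such steps This shows that the exchange left the number unmoved on both cores, but it rests on a single pair per core and does not show that the same would hold on any further core or in any other assay.

The compounds shown leave open whether a group other than chloro or bromo at this place, such as an amine or a carboxylic acid, would move the number. They also leave open how fluoro would compare with these two halogens.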